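Swapping the amide-nitrogen substituent on a fused bicyclic core

A few compounds are considered here, and "the series" means these few. Any claim that something is new, unique, unknown or untested is made for them only; others in the source may bear on it.

Of the compounds shown here, three have been tested in a functional assay on COLO 205 cells (Homo sapiens) for antiproliferative activity, read by luminescence, with a stated time of 72 h (on this read-out lower numbers stand for stronger inhibition and higher numbers for weaker inhibition), so far. Compound 1 `Cc1cnc(Nc2ccnn2C)nc1-c1cc2n(c1)C(=O)N([C@H](C)c1cccc(Cl)c1)C2` gave no single number in this assay; it is recorded as "not active" (no number reported). Compound 3 `Cc1cnc(Nc2ccnn2C)nc1-c1cn2c(c1F)CN([C@H](CO)c1cccc(Cl)c1)C2=O`, which carries a hydroxymethyl group on the benzylic carbon and a fluorine on the core, is likewise recorded as "not active" (no number reported). For the measured compounds named here, the only figure comes from compound 2 `C[C@@H](CO)Nc1ncc(Cl)c(-c2cc3n(c2)C(=O)N([C@H](CO)c2cccc(Cl)c2)C3)n1`, which has a different substituent pattern on its pyrimidine and a hydroxymethyl group on the benzylic carbon; in this assay compound 2 gives 81 nM. Compound 1 therefore stands without a number, and of the three compounds only compound 2 is placed on the scale.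

The next compound, compound 4 `Cc1cnc(Nc2ccnn2C)nc1-c1cc2n(c1)C(=O)N(Cc1ccc(F)c(F)c1)C2`, keeps the pyrimidine and the fused core of compound 1 and differs from it in one place: 3,4-difluorobenzyl in place of 1-(3-chlorophenyl)ethyl on an amide-type nitrogen in a ring. The stereocentre of compound 1 is thereby lost, and the chlorine is replaced by two fluorines.

Going by the values given here, since compound 1 has no number, no step can be sized between it and compound 4. Given that compound 1 and compound 3, which share the same pyrazolyl-aminopyrimidine, are both recorded as inactive, compound 4 is expected to remain weak, with an estimated value of 6000 nM, in a range from 1000 nM to 30000 nM.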

Compound 4, half-maximal inhibitory concentration: 293 nM
The estimate for compound 4 lay 20-fold (1.31 log units) above the measured number; the measured number lies below the stated range.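

The step from compound 1 to compound 4 cannot be read, as compound 1 has no number in this assay. Nothing measured here accounts for the activity of compound 4. The compounds shown leave open how the 3,4-difluorobenzyl group compares in size of effect with other groups on that amide-type nitrogen.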